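Flipping one ring stereocentre in a kinase inhibitor series

This account rests on a few compounds, and the source may have more. Where it says the series, first, only, none or still open, it means among the compounds named here.

Compound 1, `COc1ccc2c(c1)C[C@H](C(=O)Nc1ccc(-c3cn[nH]c3)cc1O[C@@H]1CCN(C)C1)CO2`: in an assay on isolated protein for inhibition of Rho-associated protein kinase 2 (Homo sapiens), read by HTRF, with a stated time of 4 h (on this read-out higher numbers stand for weaker inhibition and lower numbers for stronger inhibition), compound 1 gives < 1 nM, which is a limit of the assay rather than a number.
Compound 2, `COc1ccc2c(c1)C[C@H](C(=O)Nc1ccc(-c3cn[nH]c3)cc1O[C@H]1CCN(C)C1)CO2`: in this assay compound 2 gives < 1 nM, again a limit.
Compound 3, `COc1ccc2c(c1)C[C@@H](C(=O)Nc1ccc(-c3cn[nH]c3)cc1OCCCO)CO2`: in this assay compound 3 gives 35 nM.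

Among the measured compounds shown here, compound 3 therefore stands as the only measured number here; the other two results are limits. Compound 4, `COc1ccc2c(c1)C[C@H](C(=O)Nc1ccc(-c3cn[nH]c3)cc1OCCCO)CO2`, is its mirror partner at one point: the two compounds have the same atoms and bonds and differ only in configuration as drawn: 1 of 1 stereo elements differ; a stereocentre at a saturated ring carbon is drawn R in compound 3 and S in compound 4. For the measured compounds named here, the one measured step of the same kind is a step that the two limits leave unreadable from compound 1 to compound 2, and its size cannot be read because the limit of < 1 nM in this assay, at which 2 of the 3 values shown sit, hides both ends of it, even though the fact that compounds 1 and 2 differ only in the configuration as drawn makes it a clean comparison. So there is no readable precedent for how much a flip at this ring carbon matters. Without one, the expectation for compound 4 is a step of a 1.1-fold higher number from compound 3 to compound 4 (0.06 log units; within the scatter), that is none beyond the scatter, but with a wide margin either way. Compound 4 is thus estimated at 40 nM, between 8 nM and 200 nM.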

Compound 4, half-maximal inhibitory concentration: < 1 nM
Compound 4 ended at the assay's limit; the forecaster's own chance of this, stated with the estimate: 5%; middle value at least 40-fold (1.60 log units) from the limit.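

The configuration at this saturated ring carbon matters greatly in this assay: with 3-hydroxypropyl on the oxygen, the flip gives an at least 35-fold lower number from compound 3 to compound 4 (1.54 log units; beyond the scatter). That step can be assigned to this one stereocentre alone, because nothing else separates the pair: the fact that compounds 3 and 4 differ only in the configuration as drawn. Among the compounds shown here, this is the first readable size for a stereo flip in the set, while the steps among compounds 1, 2 and 4 all remain unreadable at the assay's limit.

The compounds shown leave open how 3-hydroxypropyl and 1-methylpyrrolidin-3-yl truly compare, and how the form drawn R at this carbon behaves with 1-methylpyrrolidin-3-yl on the oxygen. They also leave open whether a carboxylic acid or a longer chain in place of 3-hydroxypropyl would keep so large a gap between the two forms.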